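Swapping fluoro for bromo at one aromatic carbon

The source may hold more compounds than are shown below. What is called first, only, known or untested is meant among the compounds shown, and "the series" means these compounds.

Compound 1 `O=C1/C(=C/c2cccnc2)CN(S(=O)(=O)c2ccc([N+](=O)[O-])cc2)C/C1=C\c1ccccc1C(F)(F)F`: 15700 nM
Compound 2 `O=C1/C(=C/c2cccnc2)CN(S(=O)(=O)c2ccc(F)cc2)C/C1=C\c1ccccc1C(F)(F)F`: 16100 nM

The two numbers come from an ADME assay on L02 cells (Homo sapiens) for cytotoxicity, read by MTT assay, with a stated time of 24 h; a higher number here means a weaker inhibitor, a lower number a stronger inhibitor. In this assay, compound 2 stands at 16100 nM, level with compound 1 at 15700 nM, so repeat measurements could not tell these two compounds apart.

Compound 3 `O=C1/C(=C/c2cccnc2)CN(S(=O)(=O)c2ccc(Br)cc2)C/C1=C\c1ccccc1C(F)(F)F` has not yet been measured. It keeps everything in compound 2 except one substituent: bromo in place of fluoro on an aromatic carbon. In words, this is bromo in place of fluoro on an aromatic carbon, para to a large group.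

Among the compounds with values here, only one measured step bears on this change. Fluoro in place of nitro on that same aromatic carbon gave a 1.0-fold higher number from compound 1 to compound 2 (0.01 log units; within the scatter). Within the data shown here, that single step is thin evidence, and no bromo compound has been measured so far. Even so, the one swap seen at this carbon left the number within the scatter, so no step beyond the scatter is expected in this assay.

The estimated step is a 1.0-fold lower number from compound 2 to compound 3 (0.00 log units; within the scatter). For compound 3 the estimate is 16000 nM, with an expected range from 9000 nM to 28000 nM.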

Compound 3, half-maximal inhibitory concentration: 13300 nM
For compound 3 the middle estimate is 1.2-fold (0.08 log units) above the measured one; low and high end bracket the measured number.
By their numbers in this assay, from the lowest: compounds 3, 1 and 2 (each within the scatter of the next).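

In this assay, bromo in place of fluoro gives a 1.2-fold lower number from compound 2 to compound 3 (0.08 log units; within the scatter), and bromo in place of nitro gives a 1.2-fold lower number from compound 1 to compound 3 (0.07 log units; within the scatter). Where the earlier compounds offered a single swap at this aromatic carbon, there are now three groups, nitro, fluoro and bromo, and every pair among them sits within the scatter, so this assay does not separate compound 1, compound 2 and compound 3. Nothing measured here offers an explanation for how closely these numbers agree.

Going by these compounds, what remains open is whether this agreement extends to quite different groups on the same carbon, such as an amine or a carboxylic acid, or a longer chain, since three substituents cannot settle that for the position as a whole. On these data alone, it is also open whether changes elsewhere on the shared core, for example to the trifluoromethyl group, would leave the number just as steady as the swaps at this carbon have done.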